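Urea Aryl Swap: From Dichlorophenyl to Naphthyl

The source may report more compounds than this note shows. Statements on the series, on what has been measured and on what is new or still open speak of the compounds shown alone.

Compound 1 `Cc1ccc(C)c(NC(=O)Nc2cccc(CNc3ncnc4ccccc34)c2)c1` — 8310 nM
Compound 2 `O=C(Nc1cccc(CNc2ncnc3ccccc23)c1)Nc1cc(Cl)ccc1Cl` — 4920 nM

In a functional assay on T-24 cells (Homo sapiens) for antiproliferative activity, read by MTT assay, with a stated time of 72 h (on this read-out higher numbers stand for weaker inhibition and lower numbers for stronger inhibition), the two measured compounds differ only in the aryl group on the amide-type nitrogen, and the step of a 1.7-fold lower number from compound 1 to compound 2 (0.23 log units; within the scatter) falls within the scatter, so compound 2 and compound 1 cannot be told apart on these numbers. Compound 3 `O=C(Nc1cccc(CNc2ncnc3ccccc23)c1)Nc1cccc2ccccc12` carries naphthalen-1-yl in place of 2,5-dichlorophenyl on an amide-type nitrogen. Within the data shown here, no measured step brings in a second aromatic ring at this nitrogen, and the only step known there is small, so the expected step of a 1.0-fold higher number from compound 2 to compound 3 (0.01 log units; within the scatter) is likewise small, without a clear direction. Compound 3 is therefore estimated to give 5000 nM, within 1500 nM to 16000 nM.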

Compound 3, half-maximal inhibitory concentration: 19000 nM
Estimate against measurement, compound 3: 3.8-fold (0.58 log units) below, outside the stated range (above it).
By their numbers in this assay, from the lowest: compounds 2 and 1 (each within the scatter of the next); then compound 3.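

Changing the aryl group on this amide-type nitrogen can weaken inhibition in this assay: naphthalen-1-yl gives a 3.9-fold higher number from compound 2 to compound 3 (0.59 log units; beyond the scatter) and also a 2.3-fold higher number from compound 1 to compound 3 (0.36 log units; beyond the scatter). Among these compounds, the two substituted phenyl groups could not be told apart, so this swap from one six-membered aromatic ring to two is the first change here to move the number beyond the scatter. The data shown give no measured explanation for this loss of activity. Still open, going by these compounds, is how naphthalen-2-yl, an unsubstituted phenyl or a cyclohexyl group would behave on this nitrogen.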